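A few compounds are considered here, and "the series" means these few. Any claim that something is new, unique, unknown or untested is made for them only; others in the source may bear on it.

Compound 1 `Nc1scc(CN2CCN(c3ccc(Cl)cc3F)CC2)c1C(=O)c1ccc(Cl)cc1` gives 1%.
Compound 2 `Nc1scc(CN2CCN(c3cccnc3)CC2)c1C(=O)c1ccc(Cl)cc1` gives 0%.
Compound 3 `Nc1scc(CN2CCN(c3cc(F)ccc3F)CC2)c1C(=O)c1ccc(Cl)cc1` gives 2%.

These three numbers come from an assay on CHO cells for displacement of a labelled ligand from adenosine receptor A3 (Homo sapiens), read by scintillation counting, with a stated time of 120 min, tested at 10 uM (on this read-out lower numbers stand for less inhibition and higher numbers for more inhibition at the one concentration tested (going by the name of the read-out)), and all three compounds show next to no inhibition there. Compound 1 stands second highest of the three, yet its neighbours lie within the scatter on both sides: a number 1 percentage points lower from compound 1 to compound 2 (within the scatter) and a number 1 percentage points higher from compound 1 to compound 3 (within the scatter), and between the other two a number 2 percentage points higher from compound 2 to compound 3 (within the scatter). Compound 4 `Nc1scc(CN2CCN(c3cccc(Cl)c3)CC2)c1C(=O)c1ccc(Cl)cc1` is the next step from compound 1: 3-chlorophenyl in place of 4-chloro-2-fluorophenyl on an amine nitrogen in a ring. The three measured changes all swapped the group on the same ring nitrogen, and none moved the number beyond the scatter, so no step beyond the scatter is expected here either. Compound 4 is therefore estimated at 1%, between 0% and 8%, a step of no change at the digits printed from compound 1 to compound 4 (within the scatter) expected to stay within the scatter.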

Compound 4, a percentage reported as inhibition, at one concentration (the size of the read-out at that concentration, not a potency): 1%
Compound 4: middle estimate and measured number agree at the digits printed, and the stated range covers the measured number.
By their numbers in this assay, from the lowest: compounds 2, 1, 4 and 3 (each within the scatter of the next).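

In this assay, 3-chlorophenyl on this ring nitrogen gives no real shift from the earlier groups (no change at the digits printed from compound 1 to compound 4 (within the scatter); a number 1 percentage points lower from compound 3 to compound 4 (within the scatter); a number 1 percentage points higher from compound 2 to compound 4 (within the scatter)). A phenyl ring carrying chlorine without fluorine therefore joins the fluorinated phenyl rings and pyridin-3-yl, with all four compounds lying within the scatter of one another. No evidence is available to explain this flat result.

Going by these compounds, all four compounds carry a six-membered aromatic ring here, so the effect of a longer alkyl chain or a carboxylic acid at this position remains open. Also open, on these data alone, is whether changes elsewhere on the shared core would move the number.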